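Varying the aryl group on the triazole of compound 1

This account rests on a few compounds, and the source may have more. Where it says the series, first, only, none or still open, it means among the compounds named here.

Compound 1 `CCOC(=O)C1=Cc2ccccc2OC1(OCc1cn(-c2ccc(F)cc2)nn1)C(F)(F)F` is the only one of the three measured compounds that gives a number in a functional assay on A549 cells (Homo sapiens) for inhibition, read by MTT assay, with a stated time of 24 h; on this read-out lower numbers stand for stronger inhibition and higher numbers for weaker inhibition: compound 1 gives 7300 nM. Compound 2 `O=C(O)C1=Cc2ccccc2OC1(OCc1cc(-c2ccc(F)cc2)no1)C(F)(F)F` gives only a limit in this assay, > 150000 nM. Compound 3 `CCOC(=O)C1=Cc2ccccc2OC1(OCc1cc(-c2ccc3ccccc3c2)no1)C(F)(F)F` likewise gives only a limit, > 150000 nM. The picture is dominated by the limit of > 150000 nM in this assay, at which 2 of the 3 values shown sit. Compound 4 `CCOC(=O)C1=Cc2ccccc2OC1(OCc1cn(-c2cccc(OC)c2)nn1)C(F)(F)F` differs from compound 1 by 3-methoxyphenyl in place of 4-fluorophenyl on an aromatic nitrogen. Among the measured compounds shown here, no measured step bears on this change, so the account expects a step of modest size, if any beyond the scatter, leaning toward weaker inhibition, namely a 1.5-fold higher number from compound 1 to compound 4 (0.18 log units; within the scatter). The half-maximal inhibitory concentration of compound 4 in this assay is estimated at 11000 nM, with a range from 3000 nM to 45000 nM.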

Compound 4, half-maximal inhibitory concentration: > 150000 nM
Compound 4: no number, only a limit; the forecaster's own chance of this, stated with the estimate: 25%; middle value at least 13-fold (1.13 log units) from the limit.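

On this aromatic nitrogen, 3-methoxyphenyl in place of 4-fluorophenyl gives an at least 20-fold higher number from compound 1 to compound 4 (1.31 log units; beyond the scatter) in this assay, the first single change shown that can be read. Its size is a lower bound, since compound 4 gives only a limit. The triazole and the ethyl ester of the shared core therefore do not secure a number without 4-fluorophenyl, and the picture now rests even more on that limit: the limit of > 150000 nM in this assay, at which 3 of the 4 values shown sit.

The compounds shown leave open whether the methoxy group or its place drives this step. A 4-methoxyphenyl or 3-fluorophenyl group here would separate the two.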